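Trimming a tert-Butyl on a Weakly Active Core

A few compounds are considered here, and "the series" means these few. Any claim that something is new, unique, unknown or untested is made for them only; others in the source may bear on it.

The set was measured in a functional assay for inhibition, with Homo sapiens as the target; on this read-out higher numbers stand for weaker inhibition and lower numbers for stronger inhibition. Within the data shown here, compound 1 `Cc1nc(C(C)(C)C)n2c(O)nncc12` gives 31000 nM, the only number among the three measured compounds. Compound 2 `CCCc1nc(C)c2c(CC)cnc(Nc3cc[nH]n3)n12` returns a limit of the assay, > 48000 nM, and not a number. Compound 3 `CCCc1nc(C)c2c(C)cnc(Nc3cc[nH]n3)n12` likewise returns a limit, > 48000 nM. The change from compound 2 to compound 3 is hydrogen in place of methyl on a saturated chain carbon bound to an aromatic carbon, and the step it made, a step that the two limits leave unreadable from compound 2 to compound 3, cannot be read from these two values because of the limit of > 48000 nM in this assay, at which 2 of the 3 values shown sit. The difference between the core of compound 1 and the core of compound 2 is not broken down here.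

Compound 4 `Cc1nc(C(C)C)n2c(O)nncc12` is not yet measured. It differs from compound 1 by hydrogen in place of methyl on a saturated chain carbon bound to an aromatic carbon and two saturated chain carbons. This is the same kind of change as that from compound 2 to compound 3, though not the same: in compound 1 the place is a saturated chain carbon bound to an aromatic carbon and two saturated chain carbons, whereas in compound 2 it is a saturated chain carbon bound to an aromatic carbon only. Since the earlier step is unreadable, the expectation for compound 4 rests on compound 1 alone, whose value is 31000 nM, and on the small size of the change. The step from compound 1 to compound 4 is expected to be a 1.1-fold higher number from compound 1 to compound 4 (0.05 log units; within the scatter). For compound 4 the estimated value is 35000 nM, with a likely range from 12000 nM to 100000 nM.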

Compound 4, half-maximal inhibitory concentration: > 48000 nM
Compound 4 was reported as a limit; the forecaster's own chance of this, stated with the estimate: 35%; middle value at least 1.3-fold (0.13 log units) away from the limit.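

In this assay, going from tert-butyl to isopropyl on the core of compound 1 gives an at least 1.5-fold higher number from compound 1 to compound 4 (0.18 log units; that floor lies within the scatter), so only a floor for this step can be stated, and that floor does not stand clear of the usual scatter. Compound 4 returns > 48000 nM, which is a limit of the assay and not a number. The same kind of exchange, hydrogen in place of methyl, on the other core, between compound 2 and compound 3, cannot be read, so the series gives no two sizes to set side by side and does not show whether the change carries from one core to the other, because of where the values sit: the limit of > 48000 nM in this assay, at which 3 of the 4 values shown sit.

The compounds shown leave open how large the step from tert-butyl to isopropyl really is, since its upper end is not fixed by anything here. They also leave open what a different group at the same place on the core of compound 1 would do, such as a longer chain, an amine or a carboxylic acid in place of the tert-butyl.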